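Swapping the Two-Ring Amine for Piperidine

A few compounds are considered here, and "the series" means these few. Any claim that something is new, unique, unknown or untested is made for them only; others in the source may bear on it.

Compound 1 `O=C(CCc1ccc(C(F)(F)F)cc1)Nc1ccc2nc(N3CCC(c4ccccc4)C3)ccc2c1`: 1770 nM
Compound 2 `O=C(CCc1ccc(C(F)(F)F)cc1)Nc1ccc2nc(N3CCC4(CCNC4)C3)ccc2c1`: 140 nM

Among the compounds with values here, in a functional assay on HEK293 cells for activation of melanin-concentrating hormone receptor 1 (Rattus norvegicus), read by inositol phosphate accumulation (a higher number here means that more compound is needed for the effect, a lower number that less compound is needed), compound 2 stands lowest of the two measured numbers, with compound 1 as its only neighbour. Within the data shown here, the step of a 13-fold lower number from compound 1 to compound 2 (1.10 log units; beyond the scatter) is the one measured change at this position, and it is large. Compound 3 `O=C(CCc1ccc(C(F)(F)F)cc1)Nc1ccc2nc(N3CCCCC3)ccc2c1` reverses the direction of that change: a group of 6 heavy atoms (5 carbon, 1 nitrogen; one six-membered non-aromatic ring with 1 hetero atom) in place of a group of 9 heavy atoms (7 carbon, 2 nitrogen; 2 five-membered non-aromatic rings with 1 hetero atom each), on an aromatic carbon. Among the measured compounds shown here, since the one relevant step showed a large drop when the two-ring amine entered, its departure in compound 3 is expected to bring a large rise, estimated as a 14-fold higher number from compound 2 to compound 3 (1.15 log units; beyond the scatter). Compound 3 is therefore expected to give about 2000 nM, within a range from 600 nM to 7000 nM.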

Compound 3, half-maximal effective concentration: 110 nM
Estimate against measurement, compound 3: 18-fold (1.26 log units) above, and the stated range ends above it.
By their numbers in this assay, from the lowest: compounds 3 and 2 (each within the scatter of the next); then compound 1.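

In this assay the step of a 1.3-fold lower number from compound 2 to compound 3 (0.10 log units; within the scatter) shows that piperidin-1-yl and the two-ring amine cannot be told apart at this position, so neither the second ring nor the hydrogen-bond donor of compound 2 is required for a number of this size. The step of a 16-fold lower number from compound 1 to compound 3 (1.21 log units; beyond the scatter) leaves compound 1, with 3-phenylpyrrolidin-1-yl, alone at the high end. No measurement shown explains this result. On these data alone, whether the gap comes from the phenyl ring or the five-membered ring of compound 1 remains open, and a plain pyrrolidin-1-yl at this place would separate the two.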